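The source may hold more compounds than are shown below. What is called first, only, known or untested is meant among the compounds shown, and "the series" means these compounds.

In a functional assay on HUVEC cells (Homo sapiens) (on this read-out lower numbers stand for an effect already at smaller amounts and higher numbers for an effect only at larger amounts of compound), compound 1 `COC1=C(C)C(=O)/C(=C(O)/C=C/c2ccc(F)cc2)C(=O)C1(C)C` is known only through a limit, < 4 ug/mL. Compound 2 `COC1=C(C)C(=O)/C(=C(O)/C=C/c2cc(C)cc(C)c2)C(=O)C1(C)C` is likewise known only through a limit, < 4 ug/mL, so no number fixes its place. Both results sit together, and the evidence amounts to the limit of < 4 ug/mL in this assay, at which 2 of the 2 values shown sit. Compound 3 `COC1=C(C)C(=O)/C(=C(O)/C=C/c2ccco2)C(=O)C1(C)C` changes one group of compound 2: furan-2-yl in place of 3,5-dimethylphenyl on a double-bonded chain carbon bound to a double-bonded chain carbon. Among the compounds with values here, the only measured step bearing on this is a step that the two limits leave unreadable from compound 1 to compound 2, which also exchanges the aromatic group at this place but has no readable size. That step gives no basis for predicting a shift in either direction, so no step beyond the scatter is expected in this assay. The expected step is a step that the limit leaves unreadable from compound 2 to compound 3. Compound 3 is expected at about 2 ug/mL. For compound 3, the estimated range runs from 0.6 ug/mL to 6 ug/mL.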

Compound 3, concentration for half-maximal effect: < 4 ug/mL
Compound 3: a limit, no number; the forecaster's own chance of this, stated with the estimate: 65%; the middle value lies beyond the limit too.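

Compound 3 is, like compound 1 and compound 2, known only through a limit in this assay, so the steps from compound 1 and from compound 2 to compound 3 cannot be read. The compounds shown leave open how their actual values compare, as all that is available is a shared limit: the limit of < 4 ug/mL in this assay, at which 3 of the 3 values shown sit.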